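A few compounds are considered here, and "the series" means these few. Any claim that something is new, unique, unknown or untested is made for them only; others in the source may bear on it.

Of the compounds shown here, three built on one shared core have been measured in an assay on isolated protein with Bile acid receptor (Homo sapiens) as the target; on this read-out higher numbers stand for an effect only at larger amounts of compound and lower numbers for an effect already at smaller amounts. Compound 1 `COC(=O)/C=C/c1cccc(N(Cc2ccc(-c3cccc(C)c3)cc2)C(=O)C2CCCCC2)c1` gives 109 nM. Compound 3 `COC/C=C/c1ccc(CN(C(=O)C2CCCCC2)c2cccc(/C=C/C(=O)OC)c2)cc1` gives 233 nM. Compound 2 `COC(=O)/C=C/c1ccc(CN(C(=O)C2CCCCC2)c2cccc(/C=C/C(=O)OC)c2)cc1` returns > 1000 nM, which is not a number but a limit of the assay (the limit of > 1000 nM in this assay, at which 1 of the 3 values shown sits). Among the two numbers, compound 3 stands highest; the nearest number lies a step away of a 2.1-fold higher number from compound 1 to compound 3 (0.33 log units; beyond the scatter). The measured steps that touch compound 2 are an at least 9.1-fold higher number from compound 1 to compound 2 (0.96 log units; beyond the scatter) and, in the other direction, an at least 4.2-fold lower number from compound 2 to compound 3 (0.63 log units; beyond the scatter).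

Compound 4 `COC(=O)/C=C/c1cccc(N(Cc2ccc(/C=C/c3ccc(OC)cc3)cc2)C(=O)C2CCCCC2)c1` has not yet been measured. It differs from compound 3 in one place: 4-methoxyphenyl in place of methoxymethyl on a double-bonded chain carbon bound to a double-bonded chain carbon. Among the compounds with values here, no measured step makes this exact exchange. The step of a 2.1-fold higher number from compound 1 to compound 3 (0.33 log units; beyond the scatter) shows that a 3-methylphenyl group directly on the aromatic carbon gave a lower number than the 3-methoxyprop-1-en-1-yl chain, and the step of an at least 4.2-fold lower number from compound 2 to compound 3 (0.63 log units; beyond the scatter) shows that what sits on the double-bonded chain carbon can move the number beyond the scatter. Bringing an aromatic ring back, as 2-(4-methoxyphenyl)ethenyl in place of 3-methoxyprop-1-en-1-yl, is therefore expected to give a step of about a 1.6-fold lower number from compound 3 to compound 4 (0.19 log units; within the scatter) in this assay, toward lower numbers, though it could also remain within the scatter. Compound 4 is thus estimated at 150 nM, with a range from 50 nM to 500 nM.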

Compound 4, half-maximal effective concentration: 208 nM
Beside the measured number, compound 4's estimate is 1.4-fold (0.14 log units) below it; low and high end bracket the measured number.
By their numbers in this assay, from the lowest: compounds 1, 4 and 3 (each within the scatter of the next, the first and the last beyond it). At a limit, above all of these: compound 2.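

In this assay, the exchange of methoxymethyl for 4-methoxyphenyl on a double-bonded chain carbon bound to a double-bonded chain carbon gives a 1.1-fold lower number from compound 3 to compound 4 (0.05 log units; within the scatter), so this position takes a six-membered aromatic ring of carbon only, with its larger count of heavy atoms, without a change that can be told from the scatter. The same group in place of methoxycarbonyl gives an at least 4.8-fold lower number from compound 2 to compound 4 (0.68 log units; beyond the scatter), while 2-(4-methoxyphenyl)ethenyl in place of 3-methylphenyl on an aromatic carbon gives a 1.9-fold higher number from compound 1 to compound 4 (0.28 log units; within the scatter), so among the groups shown at this position, methoxycarbonyl alone stands apart. Compound 2 carries a limit of the assay and not a number: the limit of > 1000 nM in this assay, at which 1 of the 4 values shown sits.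

The compounds shown leave open how the number would answer to a carboxylic acid or an amine on the double-bonded chain carbon, or to a hydroxyl in place of the methoxy group on the aromatic ring. They also do not tell whether a saturated chain in place of the ethenyl link would hold the number, or why methoxycarbonyl differs from methoxymethyl here.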